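Arginine-type side chain in the aminoacyl sulfamate series

The source may report more compounds than this note shows. Statements on the series, on what has been measured and on what is new or still open speak of the compounds shown alone.

Working notes. Three aminoacyl sulfamoyl nucleosides have been measured in a functional assay on PBMC cells (Homo sapiens) for inhibition; on this read-out higher numbers stand for weaker inhibition and lower numbers for stronger inhibition. Compound 1 `Nc1ncnc2c1ncn2[C@@H]1CO[C@H](COS(=O)(=O)NC(=O)[C@@H]2CCCN2)[C@@H](O)C1` gives 2800 nM. Compound 2 `CSCC[C@H](N)C(=O)NS(=O)(=O)OC[C@H]1OC[C@@H](n2cnc3c(N)ncnc32)[C@H](O)[C@@H]1O` gives 5200 nM. Compound 3 `CC[C@H](C)[C@H](N)C(=O)NS(=O)(=O)OC[C@H]1O[C@@H](n2cnc3c(N)ncnc32)[C@H](O)[C@@H]1O` gives 5600 nM. Compound 3 carries the highest of the three numbers, yet its gaps to compound 2 and to compound 1 both lie within the usual scatter, so no order among the three can be read from these values; they sit in one band.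

The next member is compound 4 `N=C(N)NCCC[C@H](N)C(=O)NS(=O)(=O)OC[C@H]1O[C@@H](n2cnc3c(N)ncnc32)[C@H](O)[C@@H]1O`. It differs from compound 3 in one place: a group of 7 heavy atoms (4 carbon, 3 nitrogen; no ring) in place of a group of 4 heavy atoms (4 carbon; no ring), on a saturated chain carbon bound to an amine nitrogen and a carbonyl carbon. For the measured compounds named here, three side chains of different make-up have so far given numbers within the scatter of one another, and nothing among the measured compounds separates one side chain from another. The step into compound 4 is therefore expected to be small, in either direction or none beyond the scatter, on this assay; the estimate here is a 1.0-fold lower number from compound 3 to compound 4 (0.01 log units; within the scatter).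

For compound 4 the expected value in this assay is 5500 nM, with a range from 2000 nM to 16000 nM.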

Compound 4, half-maximal inhibitory concentration: 1000 nM
The estimate for compound 4 lay 5.5-fold (0.74 log units) above the measured number, and the stated range ends above it.
By their numbers in this assay, from the lowest: compound 4; then compounds 1, 2 and 3 (each within the scatter of the next).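

In this assay the position on a saturated chain carbon bound to an amine nitrogen and a carbonyl carbon now proves responsive to its substituent: replacing sec-butyl with the group of 7 heavy atoms (4 carbon, 3 nitrogen; no ring) gives a step beyond the scatter (a 5.6-fold lower number from compound 3 to compound 4 (0.75 log units; beyond the scatter)). For the compounds shown here, the earlier compounds could not show this, as no pair among them differs in one place, so this single pair is the first direct reading of a side-chain change, and its direction is toward stronger inhibition. Nothing available accounts for the size of this step, which stands for now as an observation on one pair.

The compounds shown do not separate the contribution of the chain from that of its nitrogen-bearing end, so it remains open whether a plain n-butyl chain, a chain ending in a primary amine or one ending in a carboxylic acid would give a similar step. Also open, from the compounds shown here alone, is whether the same exchange would give a step of this kind on the core of compound 1 or compound 2.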